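Ortho substituent swap on the acyl sulfonamide phenyl

The source may report more compounds than this note shows. Statements on the series, on what has been measured and on what is new or still open speak of the compounds shown alone.

Measured so far:
compound 1, `COc1cc(C(=O)NS(=O)(=O)c2ccccc2Cl)ccc1Cc1nn(C)c2ccc(NC(=O)OC3CCCC3)cc12`: 1 mg/kg
compound 2, `CCCn1cc(Cc2ccc(C(=O)NS(=O)(=O)c3ccccc3)cc2OC)c2cc(NC(=O)OC3CCCC3)ccc21`: 1 mg/kg

In a functional assay on the whole organism with Cavia porcellus as the target (a lower number here means that less compound is needed, a higher number that more compound is needed for the effect), compound 1 gives 1 mg/kg and compound 2 gives 1 mg/kg; the two lie level within the scatter, so compound 1 stands alongside compound 2, with no ordering between them.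

Compound 3, `COc1cc(C(=O)NS(=O)(=O)c2ccccc2C)ccc1Cc1nn(C)c2ccc(NC(=O)OC3CCCC3)cc12`, has not yet been measured. It differs from compound 1 as follows: methyl in place of chloro on an aromatic carbon. Among the compounds with values here, no measured pair in this set spans such a change, so the size of the step rests on expectation alone. A step within the scatter is expected, a 1.2-fold higher number from compound 1 to compound 3 (0.08 log units; within the scatter), with no direction beyond the scatter. Compound 3 is therefore estimated at 1.2 mg/kg, with a range from 0.5 mg/kg to 3 mg/kg.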

Compound 3, dose for half-maximal effect: 0.5 mg/kg
Estimate against measurement, compound 3: 2.4-fold (0.38 log units) above; measured number inside the range.
By their numbers in this assay, from the lowest: compounds 3, 1 and 2 (each within the scatter of the next).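

In this assay, the swap from 2-chlorophenyl to 2-methylphenyl gives a 2.0-fold lower number from compound 1 to compound 3 (0.30 log units; within the scatter), so the two groups stand level at this place, ortho to a large group. This is the only pair shown that differs at this position alone, and it shows that the position accepts either group without a step beyond the scatter. Nothing available bears on any reason for this result.

From the compounds shown here alone, whether an amine, a carboxylic acid or a longer chain at this place would move the number beyond the scatter remains open. Going by these compounds, whether the same swap stays level on the core of compound 2 also remains open.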